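The compounds below may be only part of what the source reports. "The series", "measured", "known", "first", "only" and "open" are said of these compounds alone.

Values so far in a functional assay on MCF7 cells (Homo sapiens) for cytotoxicity, read by MTT assay, with a stated time of 72 h; a lower number here means a stronger inhibitor, a higher number a weaker inhibitor (lower is stronger)

Compound 1 `COc1cc2ncnc(Nc3ccc(F)c(Cl)c3)c2cc1NC(=O)N/N=C/c1ccc(F)cc1` gives 35100 nM
Compound 2 `COc1cc2ncnc(Nc3ccc(F)c(Cl)c3)c2cc1NC(=O)N/N=C/c1cccc(Cl)c1Cl` gives 28700 nM
Compound 3 `COc1ccc(/C=N/NC(=O)Nc2cc3c(Nc4ccc(F)c(Cl)c4)ncnc3cc2OC)cc1` gives 8140 nM

Compound 3 has the lowest number of the three, and its gaps to both others lie beyond the scatter. Next is compound 4 `COc1cc2ncnc(Nc3ccc(F)c(Cl)c3)c2cc1NC(=O)N/N=C/c1ccc(O)c(Br)c1`, still unmeasured, which puts 3-bromo-4-hydroxyphenyl in place of 4-methoxyphenyl on a carbon with a double bond to nitrogen.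

For the measured compounds named here, three measured steps concern this same part of the structure. Two are modest: a 3.5-fold lower number from compound 2 to compound 3 (0.55 log units; beyond the scatter) with 4-methoxyphenyl replacing 2,3-dichlorophenyl, and a 4.3-fold lower number from compound 1 to compound 3 (0.63 log units; beyond the scatter) with methoxy replacing fluoro. The third separates the two halogen-bearing compounds by no more than the scatter (a 1.2-fold lower number from compound 1 to compound 2 (0.09 log units; within the scatter)). Among these three compounds, both departures from 4-methoxyphenyl carry higher numbers, and none goes against this. Going by the values given here, still, no measured compound carries a hydroxy group or a bromine, so the data say nothing direct about either.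

A modest move toward higher numbers is therefore expected, of a size no greater than the measured modest steps. The estimated move is a 1.8-fold higher number from compound 3 to compound 4 (0.27 log units; within the scatter) and remains uncertain. In this assay compound 4 is expected at 15000 nM (estimated range 5000 nM to 40000 nM).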

Compound 4, half-maximal inhibitory concentration: "not active" (no number reported)
Compound 4 has no reported number here; the estimate stays without a comparison.
By their numbers in this assay, from the lowest: compound 3; then compounds 2 and 1 (each within the scatter of the next).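

For the compounds shown here, compound 4 is reported as not active in this assay with no number attached, so no step from compound 3, or from any other compound, to compound 4 can be read. The compounds shown leave open how 3-bromo-4-hydroxyphenyl compares numerically with 4-methoxyphenyl, and what the hydroxy and bromine each contribute. Nothing available accounts for this result.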